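Trading an Alkenyl Chain for a Carboxyphenyl Group

The compounds below may be only part of what the source reports. "The series", "measured", "known", "first", "only" and "open" are said of these compounds alone.

Compound 1 `CC(C)=CCn1nc(-c2cccnc2)c2ccccc2c1=O` and compound 2 `O=c1c2ccccc2c(-c2cccnc2)nn1S(=O)(=O)c1ccccc1` share one core and differ only in the group attached to a ring nitrogen. In an assay on isolated protein (Oryctolagus cuniculus) with Thromboxane-A synthase (Homo sapiens) as the target, tested at 1 uM (a lower number here means less inhibition, a higher number more inhibition at the concentration tested (going by the name of the read-out)), compound 1 gives 94% and compound 2 gives 96%; the two numbers lie within the scatter of each other, so neither can be ranked above the other. Compound 3 `O=C(O)c1ccc(Cn2nc(-c3cccnc3)c3ccccc3c2=O)cc1` changes compound 1 in one place: 4-carboxyphenyl in place of 2-methylprop-1-en-1-yl on a saturated chain carbon bound to an aromatic nitrogen. Going by the values given here, no measured pair covers such a swap. Since compound 1 already reads 94%, little headroom remains, and the expected step from compound 1 to compound 3 is a number 2 percentage points lower from compound 1 to compound 3 (within the scatter), none beyond the scatter. Compound 3 is therefore estimated at 92%, ranging from 75% to 99%.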

Compound 3, a percentage reported as inhibition, at one concentration (the size of the read-out at that concentration, not a potency): 64%
Estimate against measurement, compound 3: 28 percentage points above; the whole stated range lies above it.
By their numbers in this assay, from the lowest: compound 3; then compounds 1 and 2 (each within the scatter of the next).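

In this assay, 4-carboxyphenyl in place of 2-methylprop-1-en-1-yl gives a number 30 percentage points lower from compound 1 to compound 3 (beyond the scatter), so the group on this saturated chain carbon does affect the read-out. The change does not remove inhibition altogether, as compound 3 still gives 64% at the tested concentration. Nothing measured here says why the number falls.

On these data alone, it remains open whether the fall follows the carboxylic acid or the aromatic ring carrying it. A plain phenyl, a methyl ester or an amine at the same place could help separate the two.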